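The compounds below may be only part of what the source reports. "The series", "measured", "known", "first", "only" and "open" are said of these compounds alone.

Working notes on the series. Compound 1 `COc1cc(-c2nn(-c3cccc(NC(=O)c4cccc(C(F)(F)F)c4)c3)cc2-c2ccncc2)ccc1Cl` has the highest of the three numbers in a functional assay on A549 cells (Homo sapiens) for inhibition, read by sulforhodamine B assay, with a stated time of 48 h (a lower number here means a stronger inhibitor of growth, a higher number a weaker inhibitor of growth), giving 1870 nM; the gap to compound 3 lies within the scatter, the gap to compound 2 beyond it. Compound 2 `O=C(Nc1cccc(-n2cc(-c3ccncc3)c(-c3ccc(Cl)c(O)c3)n2)c1)Nc1cc(C(F)(F)F)cc(C(F)(F)F)c1` gives 298 nM, and compound 3 `O=C(Nc1cccc(-n2cc(-c3ccncc3)c(-c3ccc(Cl)c(O)c3)n2)c1)Nc1ccc(Cl)c(C(F)(F)F)c1` gives 927 nM. Compound 4 `COc1cc(-c2nn(-c3cccc(NC(=O)Nc4ccc(Cl)c(Cl)c4)c3)cc2-c2ccncc2)ccc1Cl` is not yet measured. It differs from compound 1 in one place: (3,4-dichlorophenyl)amino in place of 3-(trifluoromethyl)phenyl on a carbonyl carbon. For the measured compounds named here, no measured pair shows this change directly, so the expected step of a 2.7-fold lower number from compound 1 to compound 4 (0.43 log units; beyond the scatter) is set from the spread of the three values and is moderate, toward a lower number. Compound 4 is therefore expected to give about 700 nM, with a likely range from 250 nM to 2000 nM.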

Compound 4, concentration for 50% growth inhibition: 745 nM
Compound 4: the middle estimate sits 1.1-fold (0.03 log units) below what was measured; the measured number falls inside the stated range.
By their numbers in this assay, from the lowest: compound 2; then compounds 4, 3 and 1 (each within the scatter of the next, the first and the last beyond it).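

For the compounds shown here, putting (3,4-dichlorophenyl)amino in place of 3-(trifluoromethyl)phenyl on a carbonyl carbon gives, in this assay, a 2.5-fold lower number from compound 1 to compound 4 (0.40 log units; beyond the scatter), a modest step and the first direct reading at this position. The change brings in one hydrogen-bond donor and replaces the ring substituents in a single step, so these two parts cannot be separated here. Nothing at hand accounts for the step.

On these data alone, whether the amino linker alone, with 3-(trifluoromethyl)phenyl kept, gives the same step remains open. So does how a cyclohexyl or morpholine group would read on this carbonyl carbon.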